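This account rests on a few compounds, and the source may have more. Where it says the series, first, only, none or still open, it means among the compounds named here.

Measured so far:
compound 1 `CC(C)(C)C(=O)NCCCCN1CCN(c2ccccc2Cl)CC1`: 79.4 nM
compound 2 `CC(C)(C)C(=O)NCCCCN1CCN(c2ccc(Cl)cc2)CC1`: 12.6 nM
compound 3 `CC(C)(C)C(=O)NCCCCN1CCN(c2ccc(Br)cc2)CC1`: 31.6 nM

In an assay on HEK293 cells for binding affinity to D(4) dopamine receptor (Homo sapiens), read by radioligand binding (on this read-out lower numbers stand for stronger inhibition and higher numbers for weaker inhibition), compound 2 stands lowest of the three: a 6.3-fold lower number from compound 1 to compound 2 (0.80 log units; beyond the scatter) and a 2.5-fold higher number from compound 2 to compound 3 (0.40 log units; beyond the scatter), both beyond the scatter. Every measured step alters the aryl group on the ring nitrogen; the amide side of the molecule is constant throughout.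

Compound 4 `CC(C)C(=O)NCCCCN1CCN(c2ccc(Cl)cc2)CC1` differs from compound 2 by hydrogen in place of methyl on a saturated chain carbon bound to a carbonyl carbon and two saturated chain carbons. Going by the values given here, no measured step touches this part, so none bears directly on it; the steps seen so far, of modest size, concern a different region. With nothing in the series pointing either way, the expectation is a step not beyond the scatter in this assay, a 1.3-fold higher number from compound 2 to compound 4 (0.10 log units; within the scatter). Compound 4 is therefore estimated at 16 nM, with a range from 6 nM to 45 nM.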

Compound 4, inhibition constant: 126 nM
Compound 4: the middle estimate sits 7.9-fold (0.90 log units) below what was measured, outside the stated range (above it).
By their numbers in this assay, from the lowest: compound 2; then compound 3; then compounds 1 and 4 (each within the scatter of the next).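

Tert-butyl to isopropyl is the only change on the amide side so far, and in this assay it gives a 10-fold higher number from compound 2 to compound 4 (1.00 log units; beyond the scatter), the largest listed step in the series. The amide end therefore matters to this read-out: the loss of one methyl moves the number further than any listed change to the aryl group. Nothing available explains this step. From the compounds shown here alone, whether the same step holds with 4-bromophenyl or 2-chlorophenyl in place of 4-chlorophenyl remains open. Also open, going by these compounds, is how a cyclohexyl group or a longer chain would read in place of tert-butyl.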